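The compounds below may be only part of what the source reports. "The series", "measured", "known", "first", "only" and "open" are said of these compounds alone.

Compound 1 `OC(CCn1nc2c(Br)c(Br)c(Br)c(Br)c2n1)c1ccc(F)cc1` is the reference for this step. Going by the values given here, in a functional assay on CCRF-CEM cells (Homo sapiens) for antiproliferative activity, read by MTT assay, with a stated time of 24 h, tested at 25 uM (on this read-out higher numbers stand for a weaker effect at the one concentration tested and lower numbers for a stronger effect), compound 1 gives 104%, the second highest of the three numbers measured so far. Among the compounds with values here, compound 2 `COc1cccc(C(O)CCn2nc3c(Br)c(Br)c(Br)c(Br)c3n2)c1` gives 106%, and the only measured single-point step, a number 2 percentage points higher from compound 1 to compound 2 (within the scatter), lies within the scatter. Within the data shown here, compound 3 `C[C@@H](O)CCn1nc2c(Br)c(Br)c(Br)c(Br)c2n1` gives 81%, the one number beyond the scatter from compound 1, but no single-place step links it to compound 1.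

Compound 4 `OC(CCn1nc2c(Br)c(Br)c(Br)c(Br)c2n1)c1ccccc1` differs from compound 1 by hydrogen in place of fluoro on an aromatic carbon. Among the measured compounds shown here, no measured step changes a substituent on the aryl ring in this way; the nearest comparison is the aryl exchange from compound 1 to compound 2, which moved the read-out by nothing beyond the scatter. A step of similar size, essentially none, is therefore expected. Compound 4 is estimated at 102%, between 88% and 116%, an expected step of a number 2 percentage points lower from compound 1 to compound 4 (within the scatter).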

Compound 4, a percentage reported as activity, at one concentration (the size of the read-out at that concentration, not a potency): 123%
Compound 4: the middle estimate sits 21 percentage points below what was measured; the measured number lies above the stated range.
By their numbers in this assay, from the lowest: compound 3; then compounds 1 and 2 (each within the scatter of the next); then compound 4.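

In this assay, the substituent on the aromatic ring now registers: hydrogen in place of fluoro gives a clear step (a number 19 percentage points higher from compound 1 to compound 4 (beyond the scatter)), and hydrogen in place of methoxy gives another (a number 17 percentage points higher from compound 2 to compound 4 (beyond the scatter)). Both steps point towards a weaker effect, so among these three aryl compounds the unsubstituted phenyl stands apart from the two substituted rings. Nothing measured here gives a reason for this. Still open, on these data alone, is whether a chloro or an amino group on this aromatic carbon would behave like fluoro, and whether the step holds in other assays.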